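The compounds below may be only part of what the source reports. "The series", "measured", "known", "first", "only" and "open" are said of these compounds alone.

Three compounds of a shared core differ only in the aryl group on an aromatic nitrogen. Compound 1 `Cc1ccccc1-n1nncc1CN1C(=O)C2(C(C#N)=C(N)Oc3c(N)cc4nc5ccccc5nc4c32)c2ccccc21` carries a 2-methylphenyl there; in a functional assay on HepG2 cells (Homo sapiens) for antiproliferative activity, read by MTT assay, with a stated time of 48 h (a higher number here means a weaker inhibitor, a lower number a stronger inhibitor), compound 1 reaches only the limit > 50000 nM. Compound 2 `CCc1cccc(CC)c1-n1nncc1CN1C(=O)C2(C(C#N)=C(N)Oc3c(N)cc4nc5ccccc5nc4c32)c2ccccc21` carries a 2,6-diethylphenyl and in this assay compound 2 gives 16500 nM. Compound 3 `N#CC1=C(N)Oc2c(N)cc3nc4ccccc4nc3c2C12C(=O)N(Cc1cnnn1-c1c(F)cccc1F)c1ccccc12` carries a 2,6-difluorophenyl; in this assay compound 3 again sits at the limit > 50000 nM. So compound 3 stands at the weak end of the numbers shown, and with compound 1 it shares (the limit of > 50000 nM in this assay, at which 2 of the 3 values shown sit). The measured steps are an at least 3.0-fold lower number from compound 1 to compound 2 (0.48 log units; beyond the scatter) and an at least 3.0-fold higher number from compound 2 to compound 3 (0.48 log units; beyond the scatter), while a step that the two limits leave unreadable from compound 1 to compound 3.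

Compound 4 `COc1ccc(OC)c(-n2nncc2CN2C(=O)C3(C(C#N)=C(N)Oc4c(N)cc5nc6ccccc6nc5c43)c3ccccc32)c1` now changes the same aryl group: 2,5-dimethoxyphenyl in place of 2,6-difluorophenyl on an aromatic nitrogen. The two steps that bear on it show only that a 2,6-diethylphenyl lifts the core out of the limit while a 2-methylphenyl and a 2,6-difluorophenyl do not; a 2,5-dimethoxyphenyl resembles none of these closely. The step from compound 3 to compound 4 in this assay is therefore expected to be an at least 1.2-fold lower number from compound 3 to compound 4 (0.09 log units; that floor lies within the scatter), at most a small one. Compound 4 is estimated at 40000 nM in this assay, within a range from 12000 nM to 150000 nM, with a fair chance that only a limit is reported again.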

Compound 4, half-maximal inhibitory concentration: 45100 nM
Beside the measured number, compound 4's estimate is 1.1-fold (0.05 log units) below it; the range from low to high includes it.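

In this assay compound 4 gives a measured number and not a limit, so the 2,5-dimethoxyphenyl, which brings hydrogen-bond acceptors that the 2,6-difluorophenyl lacks, is a second group on this aromatic nitrogen to leave the limit, and the 2,6-diethylphenyl is no longer the only one to do so. It does not match that group, though, as the result shows a 2.7-fold higher number from compound 2 to compound 4 (0.44 log units; beyond the scatter), and compound 2 therefore remains the strongest of the compounds shown. Against the two compounds held at a limit, the data give only an at least 1.1-fold lower number from compound 3 to compound 4 (0.04 log units; that floor lies within the scatter) and an at least 1.1-fold lower number from compound 1 to compound 4 (0.04 log units; that floor lies within the scatter), so the true size of either step stays unread, and the comparison still rests on that limit: the limit of > 50000 nM in this assay, at which 2 of the 4 values shown sit.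

Even compound 2 reaches only 16500 nM, and it remains open whether a longer chain or an isopropyl group in place of the ethyl groups would carry this trend any further. Also open, from the compounds shown here alone, are what a plain phenyl would give as a reference and whether a single methoxy group, an amine or a carboxylic acid on this aryl ring would give a readable number.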